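Cyano for methyl on the core of compound 2

The compounds below may be only part of what the source reports. "The series", "measured", "known", "first", "only" and "open" are said of these compounds alone.

Compound 1 `Cc1cnn(C(=O)NCc2ccc(OCc3ccccc3)cc2)c1` gives 1200 nM in an assay on membranes from brain for binding affinity to Fatty-acid amide hydrolase 1 (Mus musculus), read by fluorescence, with stated times of 1 h and 30 min; a higher number here means a weaker inhibitor, a lower number a stronger inhibitor. For compound 2 `Cc1cnn(C(=O)NCc2ccc(OC(c3ccccc3)c3ccccc3)cc2)c1` this assay reports only a limit, > 100000 nM. The step of an at least 83-fold higher number from compound 1 to compound 2 (1.92 log units; beyond the scatter) thus places compound 2 at the point described by the limit of > 100000 nM in this assay, at which 1 of the 2 values shown sits. Compound 3 `N#Cc1cnn(C(=O)NCc2ccc(OC(c3ccccc3)c3ccccc3)cc2)c1` differs from compound 2 by cyano in place of methyl on an aromatic carbon. Within the data shown here, no measured step covers this change, so no direction can be read from the data. Compound 3 is therefore expected to remain near the limit, with a number no higher from compound 2 to compound 3 (the limit leaves the size open) estimated as essentially no movement. Compound 3 is estimated at 100000 nM, within 20000 nM to 500000 nM.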

Compound 3, half-maximal inhibitory concentration: > 100000 nM
Compound 3: only a limit was reported; the forecaster's own chance of this, stated with the estimate: 70%; the middle value lies on the limit itself.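

Compound 2 and compound 3 both stand only as limits in this assay, so no step between them can be read: the limit of > 100000 nM in this assay, at which 2 of the 3 values shown sit.

The compounds shown leave open what cyano in place of methyl does where the value is not a limit.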